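Replacing Bromo with 2-Methylphenyl: an Expected Maximal Response

A few compounds are considered here, and "the series" means these few. Any claim that something is new, unique, unknown or untested is made for them only; others in the source may bear on it.

Of the compounds shown here, two have been measured so far in an assay on cells for activation of probable G-protein coupled receptor 34 (Mus musculus), with a stated time of 1 h; a lower number here means a smaller maximal response, a higher number a larger maximal response. Compound 1 `N[C@@H](COP(=O)(O)OCCCOC(=O)CCc1ccccc1OCc1cccc(Oc2ccc(F)cc2)c1)C(=O)O` gives 0.66 in this assay, and compound 2 `N[C@@H](COP(=O)(O)OCCCOC(=O)CCc1ccccc1OCc1cccc(Oc2ccc(Br)cc2)c1)C(=O)O` gives 0.97. For the measured compounds named here, compound 2 therefore stands highest of the two numbers; its only neighbour is compound 1, separated from it by the step a number 0.31 higher from compound 1 to compound 2 (beyond the scatter).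

Compound 3 `Cc1ccccc1-c1ccc(Oc2cccc(COc3ccccc3CCC(=O)OCCCOP(=O)(O)OC[C@H](N)C(=O)O)c2)cc1` has not yet been measured. It differs from compound 2 in one place: 2-methylphenyl in place of bromo on an aromatic carbon. Going by the values given here, the single measured step that bears on this change is the exchange of fluoro for bromo on the same aromatic carbon, a number 0.31 higher from compound 1 to compound 2 (beyond the scatter), which was large. Whether a 2-methylphenyl continues in that direction cannot be read from one step, and the value of compound 2 already lies close to the reference agonist's full response. Compound 3 is therefore expected to give about 0.9 in this assay, within a range from 0.6 to 1.1, which corresponds to an expected step of a number 0.070 lower from compound 2 to compound 3 (within the scatter).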

Compound 3, intrinsic activity: the largest response reached, as a fraction of the reference agonist's: 0.94
The estimate for compound 3 lay 0.040 below the measured number; the range from low to high includes it.
By their numbers in this assay, from the lowest: compound 1; then compounds 3 and 2 (each within the scatter of the next).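

In this assay, the aromatic carbon para to a large group tolerates much more than a single halogen: 2-methylphenyl, with 7 heavy atoms and a six-membered aromatic ring, replaces the lone bromine with no change beyond the scatter (a number 0.030 lower from compound 2 to compound 3 (within the scatter)). The exchange of fluoro for 2-methylphenyl at the same carbon (a number 0.28 higher from compound 1 to compound 3 (beyond the scatter)) shows that the rise first seen with bromo is not confined to a halogen. Among the three compounds, only the fluoro compound, compound 1, stands apart, while bromo and 2-methylphenyl remain within the scatter of each other.

As far as these compounds go, whether a phenyl without the methyl, an amine or a carboxylic acid on this carbon would hold the response remains open. No available evidence bears on what separates fluoro from the other two groups.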